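The source may report more compounds than this note shows. Statements on the series, on what has been measured and on what is new or still open speak of the compounds shown alone.

Measured compounds:
compound 1, `N=C(N)N/N=C/c1c(-c2ccncc2)nc2sc(Cl)cn12`, 3800 nM
compound 2, `Cc1cn2c(/C=N/NC(=N)N)c(-c3cccnc3)nc2s1`, 4790 nM

Of the compounds shown here, two have been measured in a functional assay (Homo sapiens) for antiproliferative activity; on this read-out higher numbers stand for weaker inhibition of growth and lower numbers for stronger inhibition of growth. Compound 1, `N=C(N)N/N=C/c1c(-c2ccncc2)nc2sc(Cl)cn12`, gives 3800 nM in this assay. Compound 2, `Cc1cn2c(/C=N/NC(=N)N)c(-c3cccnc3)nc2s1`, gives 4790 nM in this assay, the higher of the two numbers, although its gap to compound 1 lies within the usual scatter of this kind of measurement, so the two cannot be ordered with confidence.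

The next compound, compound 3, `N=C(N)N/N=C/c1c(-c2cccnc2)nc2sc(Cl)cn12`, has not yet been measured. It is derived from compound 2 by a single change: chloro in place of methyl on an aromatic carbon. Going by the values given here, no pair of measured compounds differs in one place only, so there is no measured step to lean on for this substitution. The expected step of a 1.2-fold lower number from compound 2 to compound 3 (0.08 log units; within the scatter) in this assay is therefore small and in no definite direction, not beyond the scatter. On this basis compound 3 is estimated to give 4000 nM in this assay, with a range from 1500 nM to 10000 nM.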

Compound 3, concentration for 50% growth inhibition: 13800 nM
Compound 3: middle estimate off by 3.5-fold (0.54 log units), on the low side; the measured number lies above the stated range.
By their numbers in this assay, from the lowest: compounds 1 and 2 (each within the scatter of the next); then compound 3.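

In this assay, replacing methyl with chloro on the aromatic carbon next to the ring sulfur, with pyridin-3-yl held in place, gives a 2.9-fold higher number from compound 2 to compound 3 (0.46 log units; beyond the scatter), so this position is sensitive to a swap of one heavy atom for another. With chloro held at that carbon, pyridin-3-yl in place of pyridin-4-yl gives a 3.6-fold higher number from compound 1 to compound 3 (0.56 log units; beyond the scatter), so the attachment of the pyridine matters as well; compounds 1 and 2 differ in two places and could not separate these two changes, whereas compound 3 differs from each of them in only one place and shows both single steps pointing to weaker inhibition of growth. There is no evidence here that would account for either step.

The compounds shown leave open whether the chloro-for-methyl step keeps its direction and size with pyridin-4-yl on the core, and whether the pyridine step does so with methyl at that carbon. They also leave open how other groups on this aromatic carbon, such as bromo, ethyl or an amine, would read in this assay.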